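This account rests on a few compounds, and the source may have more. Where it says the series, first, only, none or still open, it means among the compounds named here.

Compound 3 `O=S(=O)(c1cccc(F)c1)c1cn(C2CCNC2)c2ccccc12` carries a pyrrolidin-3-yl group on the aromatic nitrogen of the shared core, and in an assay on HeLa cells for displacement of a labelled ligand from 5-hydroxytryptamine receptor 6 (Homo sapiens), with a stated time of 2 h (a lower number here means a stronger inhibitor, a higher number a weaker inhibitor), compound 3 gives 4.7 nM. Its number lies between those of compound 1 `O=S(=O)(c1cccc(F)c1)c1cn(C2CCCNC2)c2ccccc12`, which in this assay gives 6 nM, and compound 2 `O=S(=O)(c1cccc(F)c1)c1cn(C2CCCNC2)c2ccc(F)cc12`, which gives 4 nM, and all three numbers sit within the usual scatter of one another.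

Compound 4 `O=S(=O)(c1cccc(F)c1)c1cn(C2CCNC2)c2ccc(F)cc12` differs from compound 3 by one change: fluoro in place of hydrogen on an aromatic carbon. The fluoro enters on a six-membered aromatic ring of carbon only, part of a fused system of two rings.

Among the compounds with values here, one measured step bears directly on this change. The same exchange of hydrogen for fluoro on the piperidin-3-yl compound gave a 1.5-fold lower number from compound 1 to compound 2 (0.18 log units; within the scatter), a step that does not rise above the scatter. The step from compound 3 to compound 4 is therefore expected to be small as well, at about a 1.2-fold lower number from compound 3 to compound 4 (0.07 log units; within the scatter), with no clear direction. The estimate for compound 4 in this assay is 4 nM, with a range from 2 nM to 8 nM.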

Compound 4, inhibition constant: 9.6 nM
Compound 4: the middle estimate sits 2.4-fold (0.38 log units) below what was measured; measured number above the stated range.
By their numbers in this assay, from the lowest: compounds 2, 3, 1 and 4 (each within the scatter of the next, the first and the last beyond it).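

In this assay, the fluoro does not behave the same on every core. With the pyrrolidin-3-yl group on the aromatic nitrogen it gives a 2.0-fold higher number from compound 3 to compound 4 (0.31 log units; beyond the scatter), so the exchange that stayed within the scatter on the piperidin-3-yl compounds is not a fixed increment: the same change on two cores in this assay, a 1.5-fold lower number (0.18 log units; within the scatter) from compound 1 to compound 2 and a 2.0-fold higher number (0.31 log units; beyond the scatter) from compound 3 to compound 4, 3.1-fold (0.49 log units) apart, beyond the scatter of two such steps The ring exchange, likewise within the scatter without the fluoro, gives a 2.4-fold higher number from compound 2 to compound 4 (0.38 log units; beyond the scatter) once the fluoro is present: the same change on two cores in this assay, a 1.3-fold lower number (0.11 log units; within the scatter) from compound 1 to compound 3 and a 2.4-fold higher number (0.38 log units; beyond the scatter) from compound 2 to compound 4, 3.1-fold (0.49 log units) apart, beyond the scatter of two such steps Among these four compounds, then, the two changes do not simply add up, and the effect of each can be read only together with the other.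

As far as these compounds go, it remains open whether this interplay also holds for other groups at this place, such as chloro or methoxy, or for a fluoro elsewhere on the same ring. Also open, from the compounds shown here alone, is how a smaller azetidin-3-yl ring or an open aminoethyl chain on the aromatic nitrogen would respond.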